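The compounds below may be only part of what the source reports. "The series", "measured", "known", "first", "only" and "open" are said of these compounds alone.

Compound 3 `CC(C)c1c(C(=O)NCc2ccccn2)nn(-c2ccc(F)cc2)c1OC[C@@H](O)C[C@@H](O)CC(=O)O` sits in the middle of a small set sharing one core. In an assay on microsomes from liver for inhibition of 3-hydroxy-3-methylglutaryl-coenzyme A reductase (Rattus norvegicus) (on this read-out lower numbers stand for stronger inhibition and higher numbers for weaker inhibition), compound 3 gives 25 nM, the second highest of the three numbers. Compound 1 `CC(C)c1c(C(=O)NCc2ccccc2)nn(-c2ccc(F)cc2)c1OC[C@@H](O)C[C@@H](O)CC(=O)O` gives 3.8 nM in this assay, while compound 2 `Cc1ccc(CN(C)C(=O)c2nn(-c3ccc(F)cc3)c(OC[C@@H](O)C[C@@H](O)CC(=O)O)c2C(C)C)cc1` gives 37 nM. The step of a 6.6-fold higher number from compound 1 to compound 3 (0.82 log units; beyond the scatter) is beyond the scatter; the step of a 1.5-fold lower number from compound 2 to compound 3 (0.17 log units; within the scatter) is within it.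

Compound 4 `COc1ccccc1CNC(=O)c1nn(-c2ccc(F)cc2)c(OC[C@@H](O)C[C@@H](O)CC(=O)O)c1C(C)C` is not yet measured. It differs from compound 3 by 2-methoxyphenyl in place of pyridin-2-yl on a saturated chain carbon bound to an amide-type nitrogen. For the measured compounds named here, the only measured step that bears on this ring is the one from compound 1 to compound 3, where the phenyl-bearing compound 1 gave the lower number; the step of a 6.6-fold higher number from compound 1 to compound 3 (0.82 log units; beyond the scatter) is modest. Going by the values given here, no measured pair shows a methoxy group on that ring, and the step of a 9.7-fold higher number from compound 1 to compound 2 (0.99 log units; beyond the scatter) combines two changes at once, so it informs only loosely.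

Because the phenyl ring of compound 1 gave 3.8 nM, compound 4 is expected to return toward that value, with a step of a 3.1-fold lower number from compound 3 to compound 4 (0.49 log units; beyond the scatter) toward a lower number. The estimate for compound 4 is 8 nM, in a range from 3 nM to 25 nM.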

Compound 4, half-maximal inhibitory concentration: 22 nM
Compound 4: the middle estimate sits 2.8-fold (0.44 log units) below what was measured; low and high end bracket the measured number.
By their numbers in this assay, from the lowest: compound 1; then compounds 4, 3 and 2 (each within the scatter of the next).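

In this assay, the replacement of pyridin-2-yl by 2-methoxyphenyl on the saturated chain carbon bound to the amide-type nitrogen gives no readable change (a 1.1-fold lower number from compound 3 to compound 4 (0.06 log units; within the scatter)), so a ring of carbon only does not by itself restore the number of compound 1. For the compounds shown here, the methoxy in place of hydrogen on an aromatic carbon is the single change that separates the two benzyl amides and it carries a step beyond the scatter (a 5.8-fold higher number from compound 1 to compound 4 (0.76 log units; beyond the scatter)), while (2-methoxybenzyl)amino and methyl(4-methylbenzyl)amino stay within the scatter of each other (a 1.7-fold lower number from compound 2 to compound 4 (0.23 log units; within the scatter)), which leaves compound 1 alone apart from the other three compounds. No measurement at hand explains why the methoxy group has this effect or why these three compounds fall together.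

The compounds shown leave open whether this step belongs to the methoxy group itself or would also appear with another group on that ring, such as fluoro, chloro or hydroxy. They also leave open how a longer chain between the amide nitrogen and the ring would read in this assay, with or without the methoxy group.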